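The compounds below may be only part of what the source reports. "The series", "measured", "known", "first", "only" and "open" are said of these compounds alone.

In a functional assay on MCF7 cells (Homo sapiens) for cytotoxicity, read by MTT assay, with a stated time of 72 h (on this read-out lower numbers stand for stronger inhibition of growth and higher numbers for weaker inhibition of growth), compound 2 `N#C[Se]c1ccc(NC(=O)Oc2ccccc2)cc1` gives 4000 nM, the lowest of the three numbers seen so far. Compound 1 `N#C[Se]c1ccc(NC(=O)Oc2ccc(F)cc2)cc1` gives 8300 nM and compound 3 `CC(C)COC(=O)Nc1ccc([Se]C#N)cc1` gives 18100 nM. Both measured steps, a 2.1-fold lower number from compound 1 to compound 2 (0.32 log units; beyond the scatter) and a 4.5-fold higher number from compound 2 to compound 3 (0.66 log units; beyond the scatter), are modest and place compound 2 at the low end. Compound 4 `N#C[Se]c1ccc(NC(=O)Oc2ccc(Cl)cc2)cc1` carries the change (chloro in place of hydrogen on an aromatic carbon). The step that bears on this is a 2.1-fold lower number from compound 1 to compound 2 (0.32 log units; beyond the scatter), the only one in which a halogen on an aromatic carbon is exchanged for hydrogen; read backwards it points to a modest rise in number on putting a halogen back. The expected step is therefore a 1.6-fold higher number from compound 2 to compound 4 (0.21 log units; within the scatter), probably beyond the scatter. Compound 4 is estimated at 6500 nM, with a range of 3000 nM to 14000 nM.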

Compound 4, concentration for 50% growth inhibition in the MCF7 assay: 6000 nM
Compound 4: the middle estimate sits 1.1-fold (0.03 log units) above what was measured, and the stated range covers the measured number.
By their numbers in the MCF7 assay, from the lowest: compounds 2, 4 and 1 (each within the scatter of the next, the first and the last beyond it); then compound 3.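

In the MCF7 assay, chloro para to a large group stays within the scatter of both hydrogen, a 1.5-fold higher number from compound 2 to compound 4 (0.18 log units; within the scatter), and fluoro, a 1.4-fold lower number from compound 1 to compound 4 (0.14 log units; within the scatter), so at this position the exchange of chloro for either group shifts the number little. In a physicochemical assay, with a stated time of 6 min, tested at 0.1 mg/mL (on this read-out higher numbers stand for more inhibition at the one concentration tested (going by the name of the read-out) and lower numbers for less inhibition), compound 2 gives > 25%, which is a limit of the assay. In the physicochemical assay, compound 4 gives > 25%, again a limit, so the step between the two cannot be read: the limit of > 25% in the physicochemical assay, at which 2 of the 2 values shown sit.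

Open, going by these compounds, is whether an amine or a carboxylic acid at this position would move the number in the MCF7 assay beyond the scatter.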